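The compounds below may be only part of what the source reports. "The series", "measured", "known", "first", "only" and "open" are said of these compounds alone.

Measured compounds:
compound 1, `Cc1ccc(-n2nncc2CN2C(=O)C3(C(C#N)=C(N)Oc4c(N)cc5nc6ccccc6nc5c43)c3ccccc32)cc1C`: > 50000 nM
compound 2, `Cc1cc(C)cc(-n2nncc2CN2C(=O)C3(C(C#N)=C(N)Oc4c(N)cc5nc6ccccc6nc5c43)c3ccccc32)c1`: 31200 nM
compound 3, `COc1ccc(OC)c(-n2nncc2CN2C(=O)C3(C(C#N)=C(N)Oc4c(N)cc5nc6ccccc6nc5c43)c3ccccc32)c1`: 28100 nM

All three share one core and differ only in the aryl group carried on an aromatic nitrogen. In a functional assay on A549 cells (Homo sapiens) for antiproliferative activity, read by MTT assay, with a stated time of 48 h (a higher number here means a weaker inhibitor, a lower number a stronger inhibitor), compound 1 gives > 50000 nM, which is a limit of the assay and not a number. Compound 2 gives 31200 nM in this assay, and compound 3 gives 28100 nM. Compound 3 thus holds the lowest of the two numbers shown, but the gap to compound 2 is small: a 1.1-fold lower number from compound 2 to compound 3 (0.05 log units; within the scatter). Against compound 1 only a floor can be stated, since the limit of > 50000 nM in this assay, at which 1 of the 3 values shown sits, applies: an at least 1.7-fold lower number from compound 1 to compound 3 (0.25 log units; that floor lies within the scatter), and likewise an at least 1.6-fold lower number from compound 1 to compound 2 (0.20 log units; that floor lies within the scatter).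

Compound 4, `N#CC1=C(N)Oc2c(N)cc3nc4ccccc4nc3c2C12C(=O)N(Cc1cnnn1-c1ccc(Cl)cc1[N+](=O)[O-])c1ccccc12`, has not yet been measured in this assay. Its change from compound 3 is 4-chloro-2-nitrophenyl in place of 2,5-dimethoxyphenyl on an aromatic nitrogen. All three measured steps are swaps of this same aryl group, and none of them moved the number beyond the scatter, so for compound 4 no step beyond the scatter is expected in either direction, although a value at the limit, as with compound 1, remains possible.

Compound 4 is therefore estimated at 30000 nM in this assay, with a range from 12000 nM to 80000 nM. The expected step from compound 3 is a 1.1-fold higher number from compound 3 to compound 4 (0.03 log units; within the scatter).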

Compound 4, half-maximal inhibitory concentration: > 50000 nM
Compound 4 was reported as a limit; the forecaster's own chance of this, stated with the estimate: 30%; middle value at least 1.6-fold (0.22 log units) away from the limit.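

The value of compound 4 in this assay is a limit of the assay and not a number, so this change can be read only as a floor: the limit of > 50000 nM in this assay, at which 2 of the 4 values shown sit. With 4-chloro-2-nitrophenyl on the aromatic nitrogen in place of 2,5-dimethoxyphenyl, the result is an at least 1.7-fold higher number from compound 3 to compound 4 (0.25 log units; that floor lies within the scatter), and in place of 3,5-dimethylphenyl it is an at least 1.6-fold higher number from compound 2 to compound 4 (0.20 log units; that floor lies within the scatter), while the step between the two limits, from compound 1 to compound 4, cannot be read. What is new is that a second, quite different aryl group now sits at the limit: compound 4 carries chloro and nitro groups, compound 1 two methyl groups, so among the compounds shown the limit is not confined to one kind of substituent, though neither floor clears the scatter.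

Every readable step at this position lies within the scatter, and the compounds shown do not tell whether any aryl group here can move the number beyond it. Also open, from the compounds shown here alone, is how an unsubstituted phenyl, a ring bearing an amine or a carboxylic acid, or a longer chain in place of the aryl group would read in this assay.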